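The compounds below may be only part of what the source reports. "The series", "measured", "known", "first", "only" and "open" are said of these compounds alone.

Compound 1 `CCOC(=O)C1=C(C)NC(=O)NC1C1CCCC1` gives 18% in an assay on HeLa cells for displacement of a labelled ligand from adenosine receptor A3 (Homo sapiens), with a stated time of 180 min, tested at 1 uM; a lower number here means less inhibition, a higher number more inhibition at the concentration tested (going by the name of the read-out). Going by the values given here, of the two numbers known, compound 1 stands highest; compound 2 `CC1=C(C(=O)OC(C)C)C(C2CCCC2)N/C(=N/C#N)N1` gives 3% in this assay, a gap beyond the scatter, though compound 2 differs from compound 1 in more than one place. Compound 3 `CC1=C(C(=O)OC(C)C)C(C2CCCC2)NC(=O)N1` carries methyl in place of hydrogen on a saturated chain carbon bound to an oxygen next to a carbonyl group and a saturated chain carbon relative to compound 1 and awaits measurement in this assay. Among the compounds with values here, with no single-change step known, the step from compound 1 to compound 3 is expected to be small, at most a modest decrease, a number 4 percentage points lower from compound 1 to compound 3 (within the scatter). Compound 3 is therefore estimated at 14%, within 2% to 28%.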

Compound 3, a percentage reported as inhibition, at one concentration (the size of the read-out at that concentration, not a potency): 7%
Compound 3: middle estimate off by 7 percentage points, on the high side, and the stated range covers the measured number.
By their numbers in this assay, from the lowest: compounds 2 and 3 (each within the scatter of the next); then compound 1.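

Ethoxy to isopropoxy gives the first single-change step in the series: in this assay the added methyl, on a saturated chain carbon bound to an oxygen next to a carbonyl group, gives a number 11 percentage points lower from compound 1 to compound 3 (beyond the scatter), a modest change beyond the scatter. This position therefore responds to one extra carbon, with the branched isopropyl on the lower side. No measured property accompanies this step, so the data offer no explanation for it. Open, as far as these compounds go, is whether a longer chain such as n-propyl, a tert-butyl group or a free carboxylic acid here would continue this decrease or reverse it. The step also leaves open whether the same change reads alike with a different group in place of cyclopentyl.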